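The compounds below may be only part of what the source reports. "The series", "measured", "known", "first", "only" and "open" are said of these compounds alone.

Of the compounds shown here, three have been measured in a functional assay on cells (Cancer cell lines, Homo sapiens) for inhibition; on this read-out lower numbers stand for stronger inhibition of growth and higher numbers for weaker inhibition of growth. Compound 1 `N=C(N)N/N=C/c1c(-c2cccs2)nc2sccn12` gives 14800 nM in this assay. Compound 2 `Cc1cc(-c2nc3sccn3c2/C=N/NC(=N)N)c(C)s1` gives 16200 nM. Compound 3 `Cc1cc(-c2nc3n(c2/C=N/NC(=N)N)CCS3)c(C)s1` gives 24000 nM. Between compound 2 and compound 1 the structural change is thiophen-2-yl in place of 2,5-dimethylthiophen-3-yl on an aromatic carbon, and this change made a 1.1-fold lower number from compound 2 to compound 1 (0.04 log units; within the scatter). Compound 3 has the highest of the three numbers, but its gaps to compound 2 and to compound 1 both lie within the scatter, so no order among the three can be read from them. The difference between the core of compound 2 and the core of compound 3 is not broken down here. Compound 4 `N=C(N)N/N=C/c1c(-c2cccs2)nc2n1CCS2` has not yet been measured. Among the compounds with values here, it differs from compound 3 by thiophen-2-yl in place of 2,5-dimethylthiophen-3-yl on an aromatic carbon, which is the same kind of change as the one between compound 2 and compound 1; around its place, the aromatic carbon is additionally two ring bonds from two ring atoms that each bear a fused ring. Because the earlier step was a 1.1-fold lower number from compound 2 to compound 1 (0.04 log units; within the scatter), the expected step in this assay is a 1.1-fold lower number from compound 3 to compound 4 (0.06 log units; within the scatter). Compound 4 is therefore estimated at 21000 nM, with a range from 10000 nM to 45000 nM.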

Compound 4, concentration for 50% growth inhibition: 17400 nM
Beside the measured number, compound 4's estimate is 1.2-fold (0.08 log units) above it, within the range that was stated.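

In this assay, putting thiophen-2-yl in place of 2,5-dimethylthiophen-3-yl on the core of compound 3 gives a 1.4-fold lower number from compound 3 to compound 4 (0.14 log units; within the scatter). Set beside the same change on the core of compound 2, the two steps cannot be told apart: the same change on two cores in this assay, a 1.1-fold lower number (0.04 log units; within the scatter) from compound 2 to compound 1 and a 1.4-fold lower number (0.14 log units; within the scatter) from compound 3 to compound 4, 1.3-fold (0.10 log units) apart, within the scatter of two such steps. This shows that the change reads the same on both cores, with each step within the scatter, but it does not show that the change has any effect of its own on growth inhibition, and two pairs of compounds say nothing about how it would read on any other core.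

At this aromatic carbon the compounds shown carry only thiophen-2-yl and 2,5-dimethylthiophen-3-yl, so how a phenyl ring, an amine or a carboxylic acid would read there remains open. The group of 6 heavy atoms is also the same in all four compounds, which leaves open what a shorter chain or an amide in its place would give.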